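Phenoxy to methoxy in a cytotoxicity series

This account rests on a few compounds, and the source may have more. Where it says the series, first, only, none or still open, it means among the compounds named here.

Compound 1 `CC1=C(C(=O)Nc2ccc(Cl)c(Cl)c2)C(c2cccc(Oc3ccccc3)c2)NC(=S)N1`: 15500 nM
Compound 2 `CC1=C(C(=O)Nc2ccc(F)c(Cl)c2)C(c2cccc(Oc3ccccc3)c2)NC(=O)N1`: 16200 nM
Compound 3 `CC1=C(C(=O)Nc2ccc(F)c(Cl)c2)C(c2cccc(Cl)c2)NC(=S)N1`: 15800 nM

Three compounds built on a shared core were tested in a functional assay on NCI/ADR-RES cells (Homo sapiens) for cytotoxicity, read by sulforhodamine B assay, with a stated time of 48 h; a lower number here means a stronger inhibitor of growth, a higher number a weaker inhibitor of growth. Compound 1 gives 15500 nM, the lowest number of the three, but its distance from compound 3 and from compound 2 lies within the scatter of the assay, so the three cannot be ranked; they sit together at the same level of growth inhibition. Among the measured compounds shown here, no single-point step between any two of them is available, since each pair differs in more than one place.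

Compound 4 `COc1cccc(C2NC(=S)NC(C)=C2C(=O)Nc2ccc(Cl)c(Cl)c2)c1` has not yet been measured in this assay. It differs from compound 1 in one place: methyl in place of phenyl on an oxygen on an aromatic ring.

For the measured compounds named here, with no measured step of this kind to lean on, and with the three values so closely grouped, the expectation for the step from compound 1 to compound 4 is for a small change, if any, in the direction of a somewhat higher number, though a result within the scatter would be no surprise. The expected step of a 1.4-fold higher number from compound 1 to compound 4 (0.13 log units; within the scatter) reflects this. Compound 4 is estimated to give 21000 nM in this assay, in the range from 9000 nM to 50000 nM.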

Compound 4, concentration for 50% growth inhibition: 16600 nM
Compound 4: the middle estimate sits 1.3-fold (0.10 log units) above what was measured; the measured number falls inside the stated range.
By their numbers in this assay, from the lowest: compounds 1, 3, 2 and 4 (each within the scatter of the next).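

Among the compounds shown here, the exchange of phenoxy for methoxy is the first comparison that isolates a single place, and in this assay it gives a 1.1-fold higher number from compound 1 to compound 4 (0.03 log units; within the scatter) with no distinction between the two compounds. A phenyl of six heavy atoms on the oxygen and a methyl of one heavy atom therefore sit at the same level of growth inhibition on the core of compound 1, so the phenyl ring is not required to reach that level in this assay. Nothing measured here offers an explanation for this flat result.

The compounds shown leave open whether a hydroxy group or an amine in place of the methoxy, or a carboxylic acid or a longer chain such as propyl on the oxygen, would stay at this level or move away from it. They also leave open whether phenoxy to methoxy would read the same way on the core of compound 2, so the flat step cannot yet be carried beyond this one pair.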